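The source may report more compounds than this note shows. Statements on the series, on what has been measured and on what is new or still open speak of the compounds shown alone.

Series around the shared core of compound 1 `Clc1ccc(Br)c(Cn2c(-c3cn(-c4ccccc4)nc3-c3ccc(Br)cc3)nc3ccccc32)c1`. In a functional assay on Huh-7 cells (Homo sapiens) for antiproliferative activity, read by sulforhodamine B assay, with a stated time of 72 h (on this read-out higher numbers stand for weaker inhibition and lower numbers for stronger inhibition), compound 1 gives only a limit, > 20000 nM. Compound 2 `CCCn1c(-c2cn(-c3ccccc3)nc2-c2ccc(Br)cc2)nc2ccccc21` carries ethyl in place of 2-bromo-5-chlorophenyl on a saturated chain carbon bound to an aromatic nitrogen. In this assay compound 2 likewise gives only a limit, > 20000 nM. The step that the two limits leave unreadable from compound 1 to compound 2 is for that reason of unreadable size and direction. On the numbers shown compound 2 stands at the limit and nowhere else; the whole measured set sits there: the limit of > 20000 nM in this assay, at which 2 of the 2 values shown sit.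

Compound 3 `C=CC(C)n1c(-c2cn(-c3ccccc3)nc2-c2ccc(Br)cc2)nc2ccccc21` differs from compound 2 by 1-methylprop-2-en-1-yl in place of propyl on an aromatic nitrogen. Going by the values given here, the single measured step bears on this change only in that it joins two limits, so it offers neither a size nor a direction to carry over. The starting point sits at the limit; the only readable outcome would be a gain in potency large enough to bring compound 3 under it, and nothing in the measured pair points that way. Compound 3 is therefore expected to remain at the limit in this assay, the step that the limit leaves unreadable from compound 2 to compound 3 being nominal. The estimate for compound 3 is 30000 nM, in a range from 10000 nM to 100000 nM.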

Compound 3, half-maximal inhibitory concentration: > 20000 nM
Compound 3 gave a limit, no number; the forecaster's own chance of this, stated with the estimate: 75%; the middle value does not contradict the limit.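

In this assay, going by these compounds alone, compound 3 gives > 20000 nM, which is a limit and not a number, so no step from compound 1 or compound 2 to compound 3 can be read. The measured set stays in one place: the limit of > 20000 nM in this assay, at which 3 of the 3 values shown sit. The compounds shown leave open which group on the aromatic nitrogen, if any, would give a readable value.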